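Dichlorophenyl in Place of Phenyl on an Antiproliferative Core

This account rests on a few compounds, and the source may have more. Where it says the series, first, only, none or still open, it means among the compounds named here.

Compound 1 `N#CC1=C(N)N(c2ccc(S(N)(=O)=O)cc2)C2=C(C(=O)CCC2)C1c1ccccc1` is the weaker of the two measured compounds: in a functional assay on Ehrlich cells (Mus musculus) for antiproliferative activity, read by trypan blue exclusion, with a stated time of 2 h, tested at 25 ug/mL (on this read-out higher numbers stand for a stronger effect at the one concentration tested and lower numbers for a weaker effect), compound 1 gives 30%. Compound 2 `N#CC1=C(N)N(c2ccc(S(N)(=O)=O)cc2)C2=C(C(=O)CCC2)C1c1ccc(O)cc1`, in this assay, gives 95%, a change of a number 65 percentage points higher from compound 1 to compound 2 (beyond the scatter). Compound 3 `N#CC1=C(N)N(c2ccc(S(N)(=O)=O)cc2)C2=C(C(=O)CCC2)C1c1ccc(Cl)cc1Cl` differs from compound 1 by 2,4-dichlorophenyl in place of phenyl on a saturated ring carbon. Among the compounds with values here, only that one measured step also alters the phenyl group, and it was large, but a different group enters here, so the evidence is thin. The expected step is a number 20 percentage points higher from compound 1 to compound 3 (beyond the scatter), a moderate rise with wide uncertainty. Compound 3 is therefore estimated at 50%, between 20% and 85%.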

Compound 3, a percentage reported as activity, at one concentration (the size of the read-out at that concentration, not a potency): 50%
Estimate against measurement, compound 3: no gap at the digits printed; measured number inside the range.
By their numbers in this assay, from the lowest: compound 1; then compound 3; then compound 2.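

Replacing phenyl with 2,4-dichlorophenyl on the saturated ring carbon gives a number 20 percentage points higher from compound 1 to compound 3 (beyond the scatter) in this assay and so shows that this position can also gain from a group without hydroxy. Going from 4-hydroxyphenyl to 2,4-dichlorophenyl gives a number 45 percentage points lower from compound 2 to compound 3 (beyond the scatter) and so the gain with the two chlorines stays well short of the gain with hydroxy. No measured evidence here says why these groups differ. Still open, going by these compounds, is whether a single chlorine would do as much as two. How an amine or a methoxy group on the same phenyl would compare also remains to be seen.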